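Inverting one chain stereocentre of compound 1

The source may report more compounds than this note shows. Statements on the series, on what has been measured and on what is new or still open speak of the compounds shown alone.

In a functional assay on HBL-100 cells (Homo sapiens) for antiproliferative activity, read by luminescence and CellTiter-Glo, with a stated time of 48 h (on this read-out higher numbers stand for weaker inhibition and lower numbers for stronger inhibition), compound 1 `C[C@H](Cc1ccccc1)[C@H]1CCCC(=O)O1` reads > 100000 nM, which is a limit of the assay and not a number. Compound 2 `O=C1C=CC[C@@H]([C@H]2C[C@@H]2c2ccccc2)O1` gives 34900 nM, and compound 3 `O=C1C=CC[C@H](/C=C/c2ccc([N+](=O)[O-])cc2)O1` gives 6700 nM; both return measured numbers. Compound 4 `C[C@@H](Cc1ccccc1)[C@H]1CCCC(=O)O1` has the same atoms and bonds as compound 1 and differs only in configuration as drawn: the two compounds have the same atoms and bonds and differ only in configuration as drawn: 1 of 2 stereo elements differ; a stereocentre at a saturated chain carbon is drawn R in compound 1 and S in compound 4. A stereocentre at a saturated chain carbon is drawn R in compound 1 and S in compound 4. Among the compounds with values here, no measured pair shows what such a change does. The step of a number no higher from compound 1 to compound 4 (the limit leaves the size open) is expected to stay within the scatter in this assay, with no clear direction. The estimate for compound 4 is 100000 nM, with an expected range from 40000 nM to 200000 nM.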

Compound 4, half-maximal inhibitory concentration: > 100000 nM
Compound 4 gave a limit, no number; the forecaster's own chance of this, stated with the estimate: 70%; the middle value sits exactly at the limit.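

Compound 1 and compound 4 both return limits of the assay, not numbers, and no step can be read between them. The compounds shown leave open whether configuration at the saturated chain carbon affects antiproliferative activity.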